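The source may report more compounds than this note shows. Statements on the series, on what has been measured and on what is new or still open speak of the compounds shown alone.

Within the data shown here, in a physicochemical assay for lipophilicity, measured as octanol-water partition (on this read-out lower numbers stand for lower lipophilicity and higher numbers for higher lipophilicity), compound 1 `COC(=O)c1cn(C/C=C(/C)CC/C=C(\C)CCC=C(C)C)nn1` gives 5.25 and so holds the higher of the two numbers so far. Compound 2 `CCCCCc1cn(CC=C(C)C)nn1` gives 3.46 as its number, lower by more than the usual scatter. Among the measured compounds shown here, compound 3 `CC(C)=CCC/C(C)=C/CC/C(C)=C\Cn1cc(-c2ccccc2)nn1` carries phenyl in place of methoxycarbonyl on an aromatic carbon and no measured pair shows this swap. The entering group holds carbon only while the leaving group also holds oxygen, so from compound 1 at 5.25 a clear upward step in this assay is expected, beyond the scatter. The estimated step is a number 1.55 log units higher from compound 1 to compound 3 (beyond the scatter) in size. Compound 3 is expected at 6.8 with 6.1 and 7.5 as the ends of the estimated range.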

Compound 3, partition coefficient: 6.95
Beside the measured number, compound 3's estimate is 0.15 log units below it, within the range that was stated.
By their numbers in this assay, from the lowest: compound 2; then compound 1; then compound 3.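

Among these compounds, replacing methoxycarbonyl with phenyl on this aromatic carbon gives, in this assay, a number 1.70 log units higher from compound 1 to compound 3 (beyond the scatter), the first comparison in which only one place changes. The read-out therefore responds strongly to the group at this position, even with the rest of the molecule held the same. No measurement here accounts for the size of this step.

On these data alone, how a carboxylic acid, an amine or a simple methyl at this carbon would compare remains open. So does whether the same swap gives a similar step on a shorter chain.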